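A few compounds are considered here, and "the series" means these few. Any claim that something is new, unique, unknown or untested is made for them only; others in the source may bear on it.

Working notes on the chromone acrylamide series.

The whole-organism read-out is a functional assay on the whole organism for inhibition, with Rattus norvegicus as the target, with a stated time of 30 min, at a dose of 1 mg/kg by the intravenous route; on this read-out lower numbers stand for less inhibition and higher numbers for more inhibition at the one dose given (going by the name of the read-out). For the measured compounds named here, compound 1 `CN1CCN(C(=O)/C=C/c2coc3ccccc3c2=O)CC1` carries the shared core joined through a double-bonded chain to a carbonyl bearing a methylpiperazine; in this assay compound 1 gives 0%, so the one measured member of the set shows no inhibition at the dose tested. Compound 2 `O=C(Cl)c1coc2ccccc2c1=O` is the acid chloride on the core itself; in this assay compound 2 returns "nd(insoluble)" (no result reported), so no number exists for it. Compound 3 `O=C(Cl)/C=C/c1coc2ccccc2c1=O` extends that acid chloride through the double-bonded chain; in this assay compound 3 likewise returns "nd(insoluble)" (no result reported), and it stands without a single number, one of two such entries in the set.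

Compound 4 `O=C(/C=C/c1coc2ccccc2c1=O)Nc1nnn[nH]1` is reached from compound 3 by the change ((1H-tetrazol-5-yl)amino in place of chloro on a carbonyl carbon). Going by the values given here, no step between measured compounds is available, so no measured size can be put beside this change; the only measured value in the set, that of compound 1, is a zero, and the closest analogue of compound 4, an amide on the same chain, is therefore without inhibition. On that basis no movement beyond the scatter is expected for compound 4, in either direction. Compound 4 is expected to give about 8% in this assay, within a range of 0% to 30%.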

Compound 4, a percentage reported as inhibition, in the whole organism at one dose (the size of the read-out at that dose, not a potency): 65%
Beside the measured number, compound 4's estimate is 57 percentage points below it, outside the stated range (above it).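

In this assay, the carbonyl carbon on the double-bonded chain proves to be a place where the group attached decides the outcome: (1H-tetrazol-5-yl)amino in place of 4-methylpiperazin-1-yl gives a number 65 percentage points higher from compound 1 to compound 4 (beyond the scatter). For the compounds shown here, the earlier compounds offered no comparison, since only one of them had a number, so this is the first sign that the series can show inhibition at the one dose given and that the shared core with this chain does not by itself rule it out. The entries for compound 2 and compound 3 carry no number, so steps from them cannot be read, and nothing available explains the size of the step from the methylpiperazine amide to the tetrazolyl amide.

The compounds shown leave open whether the tetrazole ring itself is required, or whether a carboxylic acid, a simple primary amide or an aminopyridine on the same carbonyl carbon would serve as well. Going by these compounds alone, they also leave open whether the double-bonded chain matters, as a saturated chain or a longer chain carrying the same (1H-tetrazol-5-yl)amino group has no counterpart here, and a single dose gives no measure of potency.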